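From chloro to methoxy on the weakest compound so far

A few compounds are considered here, and "the series" means these few. Any claim that something is new, unique, unknown or untested is made for them only; others in the source may bear on it.

In a functional assay on MKN-45 cells (Homo sapiens) for antiproliferative activity, read by MTT assay, with a stated time of 72 h (a higher number here means a weaker inhibitor, a lower number a stronger inhibitor), compound 1 (`COc1cc(CCc2ccccc2Cl)cc(OC)c1O`) gives 24500 nM and stands highest of the three measured numbers, making it the weakest inhibitor of the set. There, compound 3 (`COc1cc(CCc2ccc(Cl)cc2Cl)cc(OC)c1O`) gives 4460 nM and compound 2 (`COc1cc(CCc2cccc(Cl)c2Cl)cc(OC)c1O`) gives 11 nM on the shared core. Compound 4 (`COc1ccccc1CCc1cc(OC)c(O)c(OC)c1`) is still unmeasured and carries methoxy in place of chloro on an aromatic carbon.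

For the measured compounds named here, two measured steps bear on this only indirectly, each being chloro in place of hydrogen on an aromatic carbon. One shows a 2200-fold lower number from compound 1 to compound 2 (3.35 log units; beyond the scatter) and is large, while the other shows a 5.5-fold lower number from compound 1 to compound 3 (0.74 log units; beyond the scatter) and is modest. Compound 4 lacks the added chloro of compound 2 and compound 3, and the data hold no direct case of this swap. A large gain is therefore not expected. The expected step is a 1.5-fold lower number from compound 1 to compound 4 (0.19 log units; within the scatter) and nothing beyond the scatter is foreseen. In this assay the estimated value for compound 4 is 16000 nM within an expected range from 3000 nM to 60000 nM as its likely span.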

Compound 4, half-maximal inhibitory concentration: 2480 nM
Compound 4: middle estimate off by 6.5-fold (0.81 log units), on the high side, outside the stated range (below it).
By their numbers in this assay, from the lowest: compound 2; then compounds 4 and 3 (each within the scatter of the next); then compound 1.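

On an aromatic carbon ortho to a large group, methoxy in place of chloro gives a 9.9-fold lower number from compound 1 to compound 4 (0.99 log units; beyond the scatter) in this assay. The earlier steps shown here changed the compound only by adding a second chloro to compound 1, leaving the original chloro in place, so they said nothing about replacing it. Compound 4 now shows that this chloro can be exchanged and that the core of compound 1 does not need it to reach a lower number. No measured evidence is available to explain this step.

As far as these compounds go, it remains open whether an amine, a hydroxyl or ethoxy in the same place would follow methoxy. From the compounds shown here alone, it is also open whether methoxy would keep its effect alongside the second chloro that compound 2 carries.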